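The source may hold more compounds than are shown below. What is called first, only, known or untested is meant among the compounds shown, and "the series" means these compounds.

Measured compounds in a functional assay on A549 cells (Homo sapiens) for antiproliferative activity, read by MTT assay, with a stated time of 48 h; a higher number here means a weaker inhibitor, a lower number a stronger inhibitor: compound 1 `O=C(/C=C/c1ccccc1)Nc1ccc2ncnc(Nc3cccc(Br)c3)c2c1` gives 3.96 ug/mL; compound 2 `O=C(/C=C/c1ccc(Br)cc1)Nc1ccc2ncnc(Nc3cccc(Br)c3)c2c1` gives 15.3 ug/mL; compound 3 `COc1ccccc1/C=C/C(=O)Nc1ccc2ncnc(Nc3cccc(Br)c3)c2c1` gives 3.55 ug/mL.

Compound 2 stands highest of the three, with compound 1 and compound 3 both clearly lower than it. The next compound is compound 4 `O=C(/C=C/c1cccs1)Nc1ccc2ncnc(Nc3cccc(Br)c3)c2c1`, which differs from compound 2 by thiophen-2-yl in place of 4-bromophenyl on a double-bonded chain carbon bound to a double-bonded chain carbon. Going by the values given here, two measured steps bear on this change. The step of a 3.9-fold higher number from compound 1 to compound 2 (0.59 log units; beyond the scatter) shows that adding bromo to the unsubstituted ring raised the number, and the step of a 4.3-fold lower number from compound 2 to compound 3 (0.63 log units; beyond the scatter) shows that exchanging the 4-bromophenyl for another aryl lowered it again. Both point the same way: removing the 4-bromophenyl from compound 2 should bring the number back down, by a modest amount. The expected step is a 3.4-fold lower number from compound 2 to compound 4 (0.53 log units; beyond the scatter), giving compound 4 an estimated 4.5 ug/mL in this assay, within 2 ug/mL to 12 ug/mL.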

Compound 4, half-maximal inhibitory concentration: 4.66 ug/mL
Beside the measured number, compound 4's estimate is 1.0-fold (0.02 log units) below it; the measured number falls inside the stated range.
By their numbers in this assay, from the lowest: compounds 3, 1 and 4 (each within the scatter of the next); then compound 2.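

In this assay thiophen-2-yl on this double-bonded chain carbon cannot be told apart from phenyl (a 1.2-fold higher number from compound 1 to compound 4 (0.07 log units; within the scatter)) or from 2-methoxyphenyl (a 1.3-fold higher number from compound 3 to compound 4 (0.12 log units; within the scatter)), while it differs clearly from 4-bromophenyl (a 3.3-fold lower number from compound 2 to compound 4 (0.52 log units; beyond the scatter)). A five-membered aromatic ring with sulfur is therefore tolerated at this place, and among the four compounds only compound 2, with its 4-bromophenyl, stands apart. Nothing on hand explains why the 4-bromophenyl stands apart.

Open, as far as these compounds go, is how a furan-2-yl ring, or an aryl ring carrying an amine or a carboxylic acid, would behave at this place.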